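The compounds below may be only part of what the source reports. "The series", "measured", "known", "first", "only" and "open" are said of these compounds alone.

Compound 3 `CC#CCn1c(N2CCC[C@@H](N)C2)nc2c1c(=O)n(Cc1ccc(Br)cc1C(=O)O)c(=O)n2C` stands at the edge of what an ADME assay on isolated protein for inhibition of Dipeptidyl peptidase 9 (Homo sapiens), with stated times of 15 min, 60 s and 20 min (a lower number here means a stronger inhibitor, a higher number a weaker inhibitor), can report: in this assay compound 3 gives > 100000 nM, which is a limit and not a number. Compound 1 `CC#CCn1c(N2CCC[C@@H](N)C2)nc2c1c(=O)n(Cc1cc(Br)ccc1C(=O)O)c(=O)n2C` also gives only a limit, > 100000 nM. Compound 2 `CC#CCn1c(N2CCC[C@@H](N)C2)nc2c1c(=O)n(Cc1cc(Cl)ccc1C(=O)O)c(=O)n2C` likewise gives a limit, > 100000 nM. Every value sits at the same limit (the limit of > 100000 nM in this assay, at which 3 of the 3 values shown sit), so the steps a step that the two limits leave unreadable from compound 1 to compound 2, a step that the two limits leave unreadable from compound 1 to compound 3 and a step that the two limits leave unreadable from compound 2 to compound 3 cannot be read in size or direction. Compound 4 `CC#CCn1c(N2CCC[C@@H](N)C2)nc2c1c(=O)n(Cc1c(OC)cccc1C(=O)O)c(=O)n2C` differs from compound 3 by 2-carboxy-6-methoxyphenyl in place of 4-bromo-2-carboxyphenyl on a saturated chain carbon bound to an aromatic nitrogen. Since no measured step can be read, the expected step is a step that the limit leaves unreadable from compound 3 to compound 4, with no direction. Compound 4 is therefore estimated at 150000 nM, within a range from 40000 nM to 1000000 nM, most likely reported again as a limit.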

Compound 4, half-maximal inhibitory concentration: > 100000 nM
Compound 4: a limit, no number; the forecaster's own chance of this, stated with the estimate: 85%; the middle value is on the limit's open side.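

Going by these compounds alone, compound 4 joins compound 1, compound 2 and compound 3 at one limit, so no new step between them can be read: the limit of > 100000 nM in this assay, at which 4 of the 4 values shown sit. On these data alone, how far each compound lies past that limit, and whether swapping these groups changes anything in this assay, stays open.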